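Moving the trifluoromethyl group around the ring

The source may hold more compounds than are shown below. What is called first, only, known or untested is meant among the compounds shown, and "the series" means these compounds.

Three closely related compounds share one core. Compound 1 `Oc1cccc(-c2cc(-c3ccc(C(F)(F)F)cc3)cc(-c3ccccc3O)n2)c1` carries a 3-hydroxyphenyl group and a 4-(trifluoromethyl)phenyl group. Compound 2 `Oc1ccc(-c2cc(-c3cccc(C(F)(F)F)c3)cc(-c3ccccc3O)n2)cc1` instead carries a 4-hydroxyphenyl group together with a 3-(trifluoromethyl)phenyl group. In a functional assay on HeLa cells (Homo sapiens) for inhibition (a lower number here means a stronger inhibitor, a higher number a weaker inhibitor), compound 1 gives only a limit, > 50000 nM. In this assay compound 2 likewise gives only a limit, > 50000 nM. Both values shown therefore sit at the same boundary, described by the limit of > 50000 nM in this assay, at which 2 of the 2 values shown sit, so compound 2 cannot be placed above or below compound 1.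

Compound 3 `Oc1ccc(-c2cc(-c3ccc(C(F)(F)F)cc3)cc(-c3ccccc3O)n2)cc1` differs from compound 2 in a single way: 4-(trifluoromethyl)phenyl in place of 3-(trifluoromethyl)phenyl on an aromatic carbon. Among the measured compounds shown here, no measured pair shows this change, so its effect is unknown. Since compound 1 and compound 2 both reach only a limit, compound 3 is expected to do the same, with a step from compound 2 to compound 3 estimated as a step that the limit leaves unreadable from compound 2 to compound 3. Compound 3 is thus expected to give about 80000 nM, in a range from 20000 nM to 300000 nM.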

Compound 3, half-maximal inhibitory concentration: > 50000 nM
Compound 3: only a limit was reported; the forecaster's own chance of this, stated with the estimate: 85%; the middle value lies beyond the limit too.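

Compound 3 also gives only a limit, so the steps to it from compound 1 and from compound 2 cannot be read in this assay: the limit of > 50000 nM in this assay, at which 3 of the 3 values shown sit.

On these data alone, whether moving the trifluoromethyl group or the hydroxy group around the shared core changes inhibition at all remains open.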